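This account rests on a few compounds, and the source may have more. Where it says the series, first, only, none or still open, it means among the compounds named here.

In a functional assay on MCF7 cells (Homo sapiens) for inhibition, read by sulforhodamine B assay (a higher number here means a weaker inhibitor of growth, a lower number a stronger inhibitor of growth), compound 1 (`Fc1ccc(-c2ccc(-c3ccc(-c4nc5ccccc5[nH]4)cc3)cc2)cc1`) gives 36200 nM and compound 2 (`FC(F)(F)c1ccc(-c2ccc(-c3ccc(-c4nc5ccccc5[nH]4)cc3)cc2)cc1`) gives 41400 nM, while compound 3 (`Oc1ccc(-c2ccc(-c3ccc(-c4nc5ccccc5[nH]4)cc3)cc2)cc1`) gives 30500 nM and so stands within the scatter of both. Compound 4 (`COc1ccc(-c2ccc(-c3ccc(-c4nc5ccccc5[nH]4)cc3)cc2)cc1`) differs from compound 3 by methyl in place of hydrogen on an oxygen on an aromatic ring, which turns hydroxy to methoxy. Going by the values given here, no measured step makes this exact change. The nearest evidence is the exchange of groups on the same aromatic carbon: a 1.2-fold lower number from compound 1 to compound 3 (0.07 log units; within the scatter) and a 1.4-fold lower number from compound 2 to compound 3 (0.13 log units; within the scatter) are both small, as is a 1.1-fold higher number from compound 1 to compound 2 (0.06 log units; within the scatter). No step beyond the scatter is therefore expected in this assay. The expected change is a 1.1-fold higher number from compound 3 to compound 4 (0.03 log units; within the scatter) in this estimate. Compound 4 is estimated at 33000 nM, with an expected range from 18000 nM to 60000 nM.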

Compound 4, concentration for 50% growth inhibition: 33300 nM
Estimate against measurement, compound 4: 1.0-fold (0.00 log units) below, within the range that was stated.
By their numbers in this assay, from the lowest: compounds 3, 4, 1 and 2 (each within the scatter of the next).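

In this assay, methyl in place of hydrogen on the oxygen gives no step beyond the scatter, with a 1.1-fold higher number from compound 3 to compound 4 (0.04 log units; within the scatter), so the position tolerates capping that oxygen as well as exchanging the whole group. Methoxy also stays within the scatter of the other groups on this aromatic carbon, with a 1.1-fold lower number from compound 1 to compound 4 (0.04 log units; within the scatter) and a 1.2-fold lower number from compound 2 to compound 4 (0.09 log units; within the scatter), so fluoro, trifluoromethyl, hydroxy and methoxy are all within the scatter of one another. Nothing given here bears on why these compounds do not separate. The compounds shown leave open whether an amine, a carboxylic acid or a longer chain on this carbon would give a step beyond the scatter. They also leave open whether any change to the shared core would do so.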